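A change from methoxymethyl to methyl on the shared core

A few compounds are considered here, and "the series" means these few. Any claim that something is new, unique, unknown or untested is made for them only; others in the source may bear on it.

Compound 1 `COc1cc(NCc2ccccc2)cc(OC)c1OC`: > 80000 nM, a limit
Compound 2 `CCCCC(=O)N(Cc1ccc(OC)c(O)c1)c1cc(OC)c(OC)c(OC)c1`: 300 nM
Compound 3 `COCC(=O)N(Cc1ccc(OC)c(O)c1)c1cc(OC)c(OC)c(OC)c1`: 460 nM

These values come from a functional assay on KYSE-450 cells (Homo sapiens) for inhibition, read by MTT assay, with a stated time of 48 h; a lower number here means a stronger inhibitor, a higher number a weaker inhibitor. Compound 1 gives > 80000 nM, which is a limit and not a number. Compound 2 gives 300 nM and compound 3 gives 460 nM, two values within the scatter of each other.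

Compound 4 `COc1ccc(CN(C(C)=O)c2cc(OC)c(OC)c(OC)c2)cc1O` differs from compound 3 in one place: hydrogen in place of methoxy on a saturated chain carbon bound to a carbonyl carbon. It has hydrogen in place of methoxy on a saturated chain carbon bound to a carbonyl carbon. Within the data shown here, one measured step bears on this place, a 1.5-fold higher number from compound 2 to compound 3 (0.19 log units; within the scatter). Among the measured compounds shown here, with that step as the only guide, no change beyond the scatter is expected in this assay. The expected step is a 1.0-fold lower number from compound 3 to compound 4 (0.01 log units; within the scatter). For compound 4 the estimated value is 450 nM, with an expected range from 150 nM to 1400 nM.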

Compound 4, half-maximal inhibitory concentration: 160 nM
For compound 4 the middle estimate is 2.8-fold (0.45 log units) above the measured one; the measured number falls inside the stated range.
By their numbers in this assay, from the lowest: compounds 4, 2 and 3 (each within the scatter of the next, the first and the last beyond it). At a limit, above all of these: compound 1.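

In this assay the change from methoxymethyl to methyl gives a 2.9-fold lower number from compound 3 to compound 4 (0.46 log units; beyond the scatter) and so shows that this saturated chain carbon bound to a carbonyl carbon can carry a change that moves the number beyond the scatter, which the earlier step there did not show. Hydrogen in place of propyl at the same place gives a 1.9-fold lower number from compound 2 to compound 4 (0.27 log units; within the scatter) and stays inside the scatter. Nothing measured here explains the gain from losing methoxy. Still open, going by these compounds, is how an amine or a carboxylic acid at this place would read, and whether a longer chain would keep the number of compound 2.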